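The source may hold more compounds than are shown below. What is called first, only, known or untested is meant among the compounds shown, and "the series" means these compounds.

The measured compounds:

Compound 1 `COc1cccc(/C=C/c2ccccc2F)c1` — in an assay on HepG2 cells for activation of nuclear factor erythroid 2-related factor 2 (Homo sapiens), read by a luciferase reporter, with a stated time of 5 h (a lower number here means that less compound is needed, a higher number that more compound is needed for the effect), compound 1 gives 3800 nM.
Compound 2 `COc1cccc(/C=C/c2ccccc2OC)c1` — in this assay compound 2 gives 4400 nM.

Going by the values given here, only one step links these two compounds: a 1.2-fold higher number from compound 1 to compound 2 (0.06 log units; within the scatter). It falls within the scatter, so compound 2, although it holds the larger of the two numbers, cannot be told apart from compound 1 on these data; the two behave as equals in this assay.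

Compound 3 `COc1cccc(/C=C/c2cc(OC)ccc2OC)c1` is the next compound to be tested. It differs from compound 2 in one place: methoxy in place of hydrogen on an aromatic carbon. Among the compounds with values here, no measured step adds a methoxy group in place of hydrogen, so nothing bears on this change directly. Within the data shown here, the only measured step, the exchange of fluoro for methoxy in a 1.2-fold higher number from compound 1 to compound 2 (0.06 log units; within the scatter), swapped one small group for another and left the number within the scatter, which hints that small additions at this part of the molecule do not move this assay much. The expected step is therefore a 1.0-fold higher number from compound 2 to compound 3 (0.01 log units; within the scatter), none beyond the scatter. For compound 3 the estimated value in this assay is 4500 nM, with a range from 1800 nM to 11000 nM.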

Compound 3, half-maximal effective concentration: > 15000 nM
Compound 3 gave a limit, no number (the forecaster's own chance of this, stated with the estimate: 10%); at least 3.3-fold (0.52 log units) between middle value and limit.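

Putting one methoxy in place of hydrogen on compound 2, on an aromatic carbon meta to a large group and para to a methoxy group, gives an at least 3.4-fold higher number from compound 2 to compound 3 (0.53 log units; beyond the scatter) in this assay. This shows that more compound is needed once this position is filled with methoxy, a clear change that the earlier exchange of fluoro for methoxy, a 1.2-fold higher number from compound 1 to compound 2 (0.06 log units; within the scatter), gave no sign of. Compound 3 has a limit of the assay and not a number, so the step has a known lower bound but no known size, and the true value could lie well past the limit: the limit of > 15000 nM in this assay, at which 1 of the 3 values shown sits.

The compounds shown do not tell whether this rise goes with the position itself, so that any added group there would do the same, or with methoxy in particular, and they give no reason for it. An amine, a hydroxyl or a carboxylic acid on the same aromatic carbon would help to separate these two readings.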